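The compounds below may be only part of what the source reports. "The series", "measured", "known", "first", "only" and "open" are said of these compounds alone.

Values in a functional assay on the whole organism with Rattus norvegicus as the target; a higher number here means that more compound is needed for the effect, a lower number that less compound is needed:
- compound 1 `COC(=O)CC/C=C\CC[C@H]1C(=O)C[C@@H](O)[C@@H]1/C=C/C[C@@](C)(O)/C=C/C=C(C)C`: > 3.16 mg/kg
- compound 2 `COC(=O)CC/C=C\CC[C@H]1C(=O)C[C@@H](O)[C@@H]1/C=C/C[C@@](C)(O)/C=C/C(C)=C(C)C`: > 3.16 mg/kg
- compound 3 `C/C=C(C)\C=C\[C@](C)(O)C/C=C/[C@H]1[C@H](O)CC(=O)[C@@H]1CC/C=C\CCC(=O)OC`: not yet measured

Compound 2 stands at > 3.16 mg/kg, which is a limit and not a number. Compound 1 stands at > 3.16 mg/kg, also a limit. The evidence so far is therefore thin: the limit of > 3.16 mg/kg in this assay, at which 2 of the 2 values shown sit. The next change removes one methyl from the end of the side chain: 1-methylprop-1-en-1-yl in place of 1,2-dimethylprop-1-en-1-yl on a double-bonded chain carbon bound to a double-bonded chain carbon. In words, 1-methylprop-1-en-1-yl enters in place of 1,2-dimethylprop-1-en-1-yl on a double-bonded chain carbon bound to a double-bonded chain carbon.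

Going by the values given here, the only measured step bearing on this is the methyl-for-hydrogen change at the neighbouring part of the same chain, a step that the two limits leave unreadable from compound 1 to compound 2. It gives neither a size nor a direction, so any expectation for this assay is weak. No clear shift is expected, and compound 3 will most likely also be reported as a limit. The expected step is a step that the limit leaves unreadable from compound 2 to compound 3, and this remains a loose estimate. The estimate for compound 3 is 4 mg/kg, with an expected range from 1 mg/kg to 10 mg/kg.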

Compound 3, dose for half-maximal effect: 1.23 mg/kg
Compound 3: the middle estimate sits 3.3-fold (0.51 log units) above what was measured; measured number inside the range.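

In this assay, placing 1-methylprop-1-en-1-yl on a double-bonded chain carbon bound to a double-bonded chain carbon, in place of 1,2-dimethylprop-1-en-1-yl, gives an at least 2.5-fold lower number from compound 2 to compound 3 (0.40 log units; beyond the scatter), so the outcome at this place does depend on which group is attached. The same group in place of 2-methylprop-1-en-1-yl gives an at least 2.5-fold lower number from compound 1 to compound 3 (0.40 log units; beyond the scatter), so both steps into compound 3 point the same way, and each fixes only a minimum size. Compound 3 is the only one of the three with a number and not a limit, the step between the other two cannot be read, and both readable steps rest on this: the limit of > 3.16 mg/kg in this assay, at which 2 of the 3 values shown sit.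

Going by these compounds, the true distance of compound 1 and compound 2 from compound 3 remains open, and so does any ranking of those two against each other. Also open, on these data alone, is whether the gain belongs to 1-methylprop-1-en-1-yl alone or would hold for a longer chain or a cyclopropyl group at the same place, and whether it would survive a carboxylic acid in place of the methyl ester.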